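Swapping the Morpholine Amide for an Anilide

The source may hold more compounds than are shown below. What is called first, only, known or untested is meant among the compounds shown, and "the series" means these compounds.

Compound 1 `O=C(Cn1cc(CN2C(=O)C(=O)c3c(Cl)ccc(Cl)c32)nn1)OC1CCCCC1` gives 9780 nM in a functional assay on MGC-803 cells (Homo sapiens) for inhibition, read by CCK-8 assay, with a stated time of 72 h; a higher number here means a weaker inhibitor, a lower number a stronger inhibitor.
Compound 2 `O=C1C(=O)N(Cc2cn(CC(=O)N3CCOCC3)nn2)c2c(Cl)ccc(Cl)c21` gives 51700 nM in this assay.
Compound 3 `O=C1C(=O)N(Cc2cn(CC(=O)N3CCCCC3)nn2)c2c(Cl)ccc(Cl)c21` gives 18700 nM in this assay.

Compound 2 carries the highest number of the three, so it is the weakest inhibitor here: its steps to compound 3 and to compound 1 both lie beyond the scatter. The change considered now takes compound 2 to compound 4 `O=C(Cn1cc(CN2C(=O)C(=O)c3c(Cl)ccc(Cl)c32)nn1)Nc1ccccc1`, with anilino in place of morpholin-4-yl on a carbonyl carbon. Among the compounds with values here, two measured steps bear on it, both starting from the same morpholine-bearing amide of compound 2 or leading away from a ring on that carbonyl carbon: a 2.8-fold lower number from compound 2 to compound 3 (0.44 log units; beyond the scatter) and a 5.3-fold higher number from compound 1 to compound 2 (0.72 log units; beyond the scatter). In both cases a ring without the extra oxygen gave a lower number. The anilino group is likewise a single six-membered ring of carbon only, here attached through a nitrogen that carries a hydrogen. Nothing measured shows how such a hydrogen-bond donor behaves in this series, so the expectation rests on the ring exchange alone, and a modest fall in the number is expected, as in a 3.4-fold lower number from compound 2 to compound 4 (0.54 log units; beyond the scatter). Compound 4 is therefore estimated at 15000 nM, within a range from 5000 nM to 45000 nM.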

Compound 4, half-maximal inhibitory concentration: 17500 nM
Compound 4: middle estimate off by 1.2-fold (0.07 log units), on the low side; low and high end bracket the measured number.
By their numbers in this assay, from the lowest: compounds 1, 4 and 3 (each within the scatter of the next); then compound 2.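

In this assay, within the data shown here, the aromatic anilino group also gives a lower number than morpholin-4-yl, with a 3.0-fold lower number from compound 2 to compound 4 (0.47 log units; beyond the scatter) on this carbonyl carbon, so that drop is not limited to the saturated rings of the earlier compounds. The anilino group cannot be told apart from piperidin-1-yl, with a 1.1-fold lower number from compound 3 to compound 4 (0.03 log units; within the scatter) on the same carbon, or from cyclohexyloxy, with a 1.8-fold higher number from compound 1 to compound 4 (0.25 log units; within the scatter) there, and so adding the amide hydrogen shows no separate effect in this small set. No accompanying measurement explains why compound 2 stands apart from the other three.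

The compounds shown do not reveal whether N-methylanilino, which lacks the amide hydrogen, would give a similar number. They also leave open how a benzylamino group, or a chlorine or methoxy group on the phenyl ring, would read at this carbonyl carbon.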